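The source may report more compounds than this note shows. Statements on the series, on what has been measured and on what is new or still open speak of the compounds shown alone.

Measured compounds so far:
- compound 1 `COc1ccc(/C=C/c2cc(OC)cc(OC)c2/C=C/C(=O)c2cccc(OC)c2)cc1`: 4.3 ug/mL
- compound 2 `COc1ccc(/C=C/c2cc(OC)cc(OC)c2/C=C/C(=O)c2cccc(Cl)c2)cc1`: 3.3 ug/mL
- compound 3 `COc1ccc(/C=C/c2cc(OC)cc(OC)c2/C=C/C(=O)c2ccc(OC)cc2)cc1`: 5.8 ug/mL

In a functional assay on B16-F10 cells (Mus musculus) for antiproliferative activity, read by MTT assay, with a stated time of 48 h (a lower number here means a stronger inhibitor, a higher number a weaker inhibitor), compound 1 gives 4.3 ug/mL, the second highest of the three numbers; its nearest neighbour is compound 2 with 3.3 ug/mL, and the furthest is compound 3 with 5.8 ug/mL. Both gaps are within the scatter, so no order among the three can be read from these numbers.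

The next compound, compound 4 `CCN(CC)c1ccc(C(=O)/C=C/c2c(/C=C/c3ccc(OC)cc3)cc(OC)cc2OC)cc1`, departs from compound 1 at the carbonyl carbon: 4-(diethylamino)phenyl in place of 3-methoxyphenyl on a carbonyl carbon

The steps measured so far all concern the same carbonyl-attached ring. The step of a 1.3-fold lower number from compound 1 to compound 2 (0.11 log units; within the scatter) and the step of a 1.3-fold higher number from compound 1 to compound 3 (0.13 log units; within the scatter) both stay within the scatter, and so does a 1.8-fold higher number from compound 2 to compound 3 (0.24 log units; within the scatter). Going by the values given here, none of the measured steps introduces a group of the same kind as the 4-(diethylamino)phenyl entering here, so there is no direct precedent for its size; what is known is that changes on this ring have so far moved this assay by no more than the scatter.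

The number for compound 4 is therefore expected to stay close to compound 1, with an expected step of a 1.0-fold higher number from compound 1 to compound 4 (0.02 log units; within the scatter), and the estimate for compound 4 is 4.5 ug/mL with a range from 1.5 ug/mL to 13 ug/mL.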

Compound 4, half-maximal inhibitory concentration: 8.1 ug/mL
Compound 4: the middle estimate sits 1.8-fold (0.26 log units) below what was measured, within the range that was stated.
By their numbers in this assay, from the lowest: compounds 2, 1, 3 and 4 (each within the scatter of the next, the first and the last beyond it).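

In this assay, going by these compounds alone, the 4-(diethylamino)phenyl group on the carbonyl carbon gives the first step in this set to pass the scatter, though only modestly and only against the 3-chlorophenyl compound (a 2.5-fold higher number from compound 2 to compound 4 (0.39 log units; beyond the scatter)). Against the two methoxy-bearing compounds, the steps remain within the scatter (a 1.9-fold higher number from compound 1 to compound 4 (0.28 log units; within the scatter); a 1.4-fold higher number from compound 3 to compound 4 (0.15 log units; within the scatter)), so this position takes a group of 11 heavy atoms in place of one of 8 with no separation from compound 1, and the single clear gap lies between compound 2 and compound 4. Nothing measured here accounts for that gap.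

The shown changes do not separate the diethylamino group's nitrogen from its two ethyl chains, so a dimethylamino group, a primary amine or a plain butyl chain on this ring would be the informative comparison, and a carboxylic acid would test a very different kind of substituent at the same place. All four compounds also share the same core, which leaves open how the methoxy groups on it, or a hydroxyl in their place, would bear on these numbers.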